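Replacing the pyridin-3-yl group of compound 1

A few compounds are considered here, and "the series" means these few. Any claim that something is new, unique, unknown or untested is made for them only; others in the source may bear on it.

In a physicochemical assay for lipophilicity (on this read-out higher numbers stand for higher lipophilicity and lower numbers for lower lipophilicity), compound 1 (`CCn1cnc2c(-c3ccc(F)c(-c4cccnc4)c3)cnnc21`) gives 2.6 as its reading. Compound 3 (`CCn1cnc2c(-c3ccc(F)c(Oc4cccc(S(=O)(=O)CC)c4)c3)cnnc21`) gives 2.3 as its reading, within the scatter of compound 1. Compound 2 (`CCn1cnc2c(-c3ccnc(Oc4cccc(S(=O)(=O)CC)c4)c3)cnnc21`) reads 1.6 and so lies lower than compound 1 by more than the scatter.

Compound 4 (`CCn1cnc2c(-c3ccc(F)c(Oc4cnc(C#N)nc4)c3)cnnc21`) has not yet been measured. It departs from compound 1 on an aromatic carbon of a six-membered aromatic ring of carbon only, ortho to a fluoro group, where pyridin-3-yl gives way to a larger group (a group of 9 heavy atoms (5 carbon, 3 nitrogen, 1 oxygen; one six-membered aromatic ring with 2 hetero atoms) in place of a group of 6 heavy atoms (5 carbon, 1 nitrogen; one six-membered aromatic ring with 1 hetero atom), on an aromatic carbon). Among the measured compounds shown here, no measured pair differs in one place, so no single step guides the expectation in this assay directly. The measured compounds that carry an oxygen-linked ring offer only a loose guide: compound 3 stands at 2.3 on this scale and compound 2 at 1.6 on the same scale. A downward step beyond the scatter is expected, estimated as a number 0.60 log units lower from compound 1 to compound 4 (beyond the scatter) on this read-out. For compound 4 the estimated value is 2 with an expected range from 1.6 to 2.4 on the same scale.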

Compound 4, distribution coefficient: 2
Compound 4: middle estimate and measured number agree at the digits printed; measured number inside the range.
By their numbers in this assay, from the lowest: compound 2; then compounds 4, 3 and 1 (each within the scatter of the next, the first and the last beyond it).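

At this position, on an aromatic carbon ortho to a fluoro group, this assay now has its first listed step: putting the larger oxygen-linked ring bearing a nitrile in place of pyridin-3-yl gives a number 0.60 log units lower from compound 1 to compound 4 (beyond the scatter). The step shows that the reading at this position can shift beyond the usual scatter even though the entering group has more heavy atoms than pyridin-3-yl. Nothing shown accounts for the size of this step.

The change brings in the oxygen, the new ring and the nitrile together, so the compounds shown leave open how much of the step belongs to each. They also leave open how a methoxy group or an amine on the same aromatic carbon would read in this assay.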